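A Pyridine Nitrogen Replaces a Carbon in Compound 2's Phenyl

The compounds below may be only part of what the source reports. "The series", "measured", "known", "first", "only" and "open" are said of these compounds alone.

Two compounds share one core and differ only in the group carried on an aromatic carbon of that core. Compound 1 `COc1cc(N2CCN(S(C)(=O)=O)CC2)ccc1Nc1ncc2cccc(NC3CCCCC3)c2n1` carries cyclohexylamino there, and compound 2 `COc1cc(N2CCN(S(C)(=O)=O)CC2)ccc1Nc1ncc2cccc(-c3ccccc3)c2n1` carries phenyl. In a functional assay on HCT-116 cells (Homo sapiens) for cytotoxicity (a lower number here means a stronger inhibitor, a higher number a weaker inhibitor), compound 1 gives 810 nM, while compound 2 gives 1740 nM. The exchange is a measured step: a 2.1-fold higher number from compound 1 to compound 2 (0.33 log units; beyond the scatter). Among the measured compounds shown here, compound 2 therefore stands highest of the two numbers known so far, with compound 1 as its only and nearest neighbour.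

Compound 3 `COc1cc(N2CCN(S(C)(=O)=O)CC2)ccc1Nc1ncc2cccc(-c3cccnc3)c2n1` is the next variation. It differs from compound 2 by pyridin-3-yl in place of phenyl on an aromatic carbon. For the measured compounds named here, no measured pair shows what this particular exchange does. Going by the values given here, the only step in hand, a 2.1-fold higher number from compound 1 to compound 2 (0.33 log units; beyond the scatter), concerns a different exchange at the same aromatic carbon and was modest, so it offers little guidance on swapping phenyl for pyridin-3-yl. Without direct precedent, the expected step is none beyond the scatter, which amounts to a 1.2-fold lower number from compound 2 to compound 3 (0.06 log units; within the scatter). Compound 3 is thus estimated at 1500 nM in this assay, within a range from 600 nM to 4000 nM.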

Compound 3, half-maximal inhibitory concentration: 1580 nM
Compound 3: middle estimate off by 1.1-fold (0.02 log units), on the low side, and the stated range covers the measured number.
By their numbers in this assay, from the lowest: compounds 1, 3 and 2 (each within the scatter of the next, the first and the last beyond it).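

In this assay, replacing phenyl with pyridin-3-yl on this aromatic carbon, which adds one ring nitrogen and one hydrogen-bond acceptor, gives a 1.1-fold lower number from compound 2 to compound 3 (0.04 log units; within the scatter) and so shows no measurable effect of the exchange on this read-out. Compared with the cyclohexylamino group at the same carbon, the new compound gives a 2.0-fold higher number from compound 1 to compound 3 (0.29 log units; within the scatter), whereas phenyl gave a 2.1-fold higher number from compound 1 to compound 2 (0.33 log units; beyond the scatter), so only phenyl is separated from cyclohexylamino by more than the usual scatter, and compound 3 falls within the scatter of both compound 1 and compound 2. No supporting measurement is available to explain why the ring nitrogen leaves the number in this cell assay essentially unmoved.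

The compounds shown leave open what a small amine such as methylamino, or a carboxylic acid, would give on this same aromatic carbon, and so how much further the number can move at this position. They also leave open whether the small differences among these three groups would look the same in a test other than this cytotoxicity read-out on one cell line.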